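Working notes: chalcone series, compound 3 to compound 4

The compounds below may be only part of what the source reports. "The series", "measured", "known", "first", "only" and "open" are said of these compounds alone.

For the measured compounds named here, compound 3 `COc1ccc(C(=O)/C=C/c2ccccn2)c2c1C=CC(C)(C)O2` gives the only number in this set: in a functional assay on HCT-116 cells (Homo sapiens) for antiproliferative activity, read by MTT assay, with a stated time of 24 h (a higher number here means a weaker inhibitor, a lower number a stronger inhibitor), compound 3 gives 6630 nM. Compound 1 `COc1ccc(C(=O)/C=C/c2ccccc2)c2c1C=CC(C)(C)O2` sits at a limit of this assay, > 10000 nM. Compound 2 `COc1ccc(C(=O)/C=C/c2ccsc2)c2c1C=CC(C)(C)O2` also sits at a limit, > 10000 nM. Two of the three values thus rest at the limit of > 10000 nM in this assay, at which 2 of the 3 values shown sit, and the steps of an at least 1.5-fold lower number from compound 1 to compound 3 (0.17 log units; that floor lies within the scatter) and an at least 1.5-fold lower number from compound 2 to compound 3 (0.17 log units; that floor lies within the scatter) are floors only. Compound 4 `COc1ccccc1/C=C/C(=O)c1ccc(OC)c2c1OC(C)(C)C=C2` differs from compound 3 by 2-methoxyphenyl in place of pyridin-2-yl on a double-bonded chain carbon bound to a double-bonded chain carbon. The step that bears on it is an at least 1.5-fold lower number from compound 1 to compound 3 (0.17 log units; that floor lies within the scatter), read in reverse: a carbon-only ring returns where pyridin-2-yl stood, and compound 1 with phenyl sits at the limit. Compound 4 is therefore expected to move back toward the limit, a step of a 1.4-fold higher number from compound 3 to compound 4 (0.13 log units; within the scatter). The estimate for compound 4 is 9000 nM, within 3000 nM to 30000 nM, with a real chance that only a limit is reported.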

Compound 4, half-maximal inhibitory concentration: > 10000 nM
Compound 4: only a limit was reported (the forecaster's own chance of this, stated with the estimate: 50%); middle value at least 1.1-fold (0.04 log units) from the limit.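

In this assay, 2-methoxyphenyl in place of pyridin-2-yl on a double-bonded chain carbon gives an at least 1.5-fold higher number from compound 3 to compound 4 (0.17 log units; that floor lies within the scatter). Compound 4 is reported only as a limit, so that step is a floor, and the steps from compound 1 and compound 2 to compound 4 cannot be read. Adding methoxy to the phenyl ring therefore yields no readable gain, and pyridin-2-yl remains the only group here with a number: the limit of > 10000 nM in this assay, at which 3 of the 4 values shown sit.

Still open, on these data alone, is whether the pyridin-2-yl reading marks a real trend, since its steps are floors within the scatter. Pyridin-4-yl or a dimethylaminophenyl at this place could test that.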